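The source may hold more compounds than are shown below. What is called first, only, known or untested is meant among the compounds shown, and "the series" means these compounds.

The compounds share one core, seen in compound 1 `O=c1n(Cc2cc3cc(Br)ccc3n2CCCCO)c2cnccc2n1C1CC1`, compound 2 `COc1ccc2c(c1)cc(Cn1c(=O)n(C3CC3)c3ccncc31)n2CCCCO` and compound 3 `CS(=O)(=O)CCCn1c(Cn2c(=O)n(C3CC3)c3ccncc32)cc2cc(F)ccc21`, and all three were tested in an ADME assay on HeLa cells (Homo sapiens) for cytotoxicity, read by ATP content, with a stated time of 3 days; on this read-out lower numbers stand for higher toxicity in this test and higher numbers for lower toxicity in this test. In this assay compound 1 gives > 50000 nM, which is a limit of the assay rather than a number. Compound 2 gives > 50000 nM, again a limit. Compound 3 gives > 50000 nM, also a limit, so its standing on the numbers shown is that of a compound without a measured toxicity value. For the measured compounds named here, the one step between measured compounds, a step that the two limits leave unreadable from compound 1 to compound 2, cannot be given a size for the same reason. Compound 4 `O=c1n(Cc2cc3cc(F)ccc3n2CCCCO)c2cnccc2n1C1CC1` has not yet been measured. It differs from compound 3 by hydroxymethyl in place of methylsulfonyl on a saturated chain carbon, three bonds along the chain from an aromatic nitrogen. Going by the values given here, no measured step covers this kind of change; what the data offer is the limit of > 50000 nM in this assay, at which 3 of the 3 values shown sit, which gives neither direction nor size. The expected step from compound 3 to compound 4 is therefore a step that the limit leaves unreadable from compound 3 to compound 4, meaning nothing beyond the scatter, and a limit is again the most likely outcome. The estimate for compound 4 in this assay is 80000 nM, with an expected range from 50000 nM to 200000 nM.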

Compound 4, half-maximal cytotoxic concentration: > 50000 nM
Compound 4: a limit, no number; the forecaster's own chance of this, stated with the estimate: 90%; the middle value does not contradict the limit.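

No new step can be read between compound 4 and compound 1, compound 2 or compound 3, because each result in this assay is a limit and not a number: the limit of > 50000 nM in this assay, at which 4 of the 4 values shown sit.

The compounds shown leave open whether swapping the bromo, methoxy and fluoro groups, or the 3-(methylsulfonyl)propyl and 4-hydroxybutyl chains, changes toxicity in this test at all.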